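The compounds below may be only part of what the source reports. "The series", "measured", "known", "first", "only" and "open" are said of these compounds alone.

In a functional assay on Jurkat cells (Homo sapiens) for antiproliferative activity, read by MTT assay, with a stated time of 72 h (a lower number here means a stronger inhibitor, a higher number a weaker inhibitor), two related compounds sit far apart. Compound 1 `COc1cc(-c2ncnn2-c2cccc(N)c2)cc(OC)c1OC` gives > 10000 nM, and this is a limit of the assay, not a measured number. Compound 2 `CCOc1ccc(-c2ncnn2-c2cc(OC)c(OC)c(OC)c2)cc1Cl` gives a true number, 3 nM, which shows that strong inhibition is reachable among these related structures. However, compound 2 differs from compound 1 in more than one place, so the two values do not isolate the effect of any single group.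

Compound 3 `COc1cc(-c2ncnn2-c2ccc(Cl)cc2)cc(OC)c1OC` keeps the core of compound 1 and changes one group: 4-chlorophenyl in place of 3-aminophenyl on an aromatic nitrogen. In words, 4-chlorophenyl stands in place of 3-aminophenyl on an aromatic nitrogen. Compound 2 also carries a chlorine and gives 3 nM, which is a weak hint in favour of activity and no more than that. The expected change in this assay is a gain in strength, an at least 3.3-fold lower number from compound 1 to compound 3 (0.52 log units; beyond the scatter), but a modest one that stays far short of compound 2. From the compounds shown here alone, compound 1 offers only a limit, so the true size of the step stays open, and compound 3 may also end up at a limit. For compound 3 the estimated value is 3000 nM, with an expected range from 300 nM to 10000 nM.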

Compound 3, half-maximal inhibitory concentration: > 10000 nM
Compound 3: a limit, no number; the forecaster's own chance of this, stated with the estimate: 35%; middle value at least 3.3-fold (0.52 log units) from the limit.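

Compound 3 gives > 10000 nM, which is a limit of the assay and not a number. Among the compounds shown here, no step from compound 1 to compound 3 can be read, because compound 1 also stands at a limit: the limit of > 10000 nM in this assay, at which 2 of the 3 values shown sit. The compounds shown leave open whether 4-chlorophenyl in place of 3-aminophenyl on an aromatic nitrogen changes the strength at all.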